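The source may hold more compounds than are shown below. What is called first, only, known or untested is meant among the compounds shown, and "the series" means these compounds.

Measured in an in vitro ADME assay on microsomes from liver (Homo sapiens) for metabolic stability, read by LC-MS; a lower number here means that the compound disappears faster, a higher number that the compound lasts longer:

Compound 1, `CC(C)N1C(=O)C(=O)N=C1/N=C(/Nc1ccc(Cl)c(Cl)c1)NC(C)(C)C`, reaches the limit of the assay in this assay, > 1 h.
Compound 2, `CC(C)N1C(=O)C(=O)N=C1/N=C(\NCCN1CCCC1)Nc1ccc(Cl)c(Cl)c1`, gives in this assay 0.886 h.
Compound 3, `CC(C)N1C(=O)C(=O)N=C1/N=C(\NCCCN(C)C)Nc1ccc(Cl)c(Cl)c1`, reaches the limit in this assay, > 1 h.

Compound 3 thus stands at a limit rather than at a number, and it shares that position with one other compound (the limit of > 1 h in this assay, at which 2 of the 3 values shown sit). The steps among the three are modest: an at least 1.1-fold lower number from compound 1 to compound 2 (0.05 log units; that floor lies within the scatter), while a step that the two limits leave unreadable from compound 1 to compound 3, and an at least 1.1-fold higher number from compound 2 to compound 3 (0.05 log units; that floor lies within the scatter).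

Compound 4, `CC(C)N1C(=O)C(=O)N=C1/N=C(\NCCCCN1CCCC1)Nc1ccc(Cl)c(Cl)c1`, has not yet been measured in this assay. It differs from compound 3 in one place: (pyrrolidin-1-yl)methyl in place of dimethylamino on a saturated chain carbon, three bonds along the chain from an amine nitrogen. Going by the values given here, the step that bears most directly on this change is the one from compound 2 to compound 3, where the same two amines were exchanged in the opposite direction, one bond closer to the amine nitrogen, and it was read only as a small floor within the scatter. The step from compound 1 to compound 2, which also introduced a pyrrolidinyl chain, was likewise no larger than the scatter. The change to compound 4 is therefore expected to move this assay by a number no higher from compound 3 to compound 4 (the limit leaves the size open), which is not beyond the scatter. Compound 4 is estimated at 1 h, between 0.5 h and 2 h, with a fair chance that the assay again reports only its limit.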

Compound 4, half-life: > 1 h
Compound 4 gave a limit, no number; the forecaster's own chance of this, stated with the estimate: 50%; the middle value sits exactly at the limit.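

Compound 4 stands at a limit in this assay, which shows that a pyrrolidin-1-yl group at the end of the chain does not by itself yield a readable number, as it did in compound 2, once that group is carried on 4-(pyrrolidin-1-yl)butyl. Going by these compounds alone, the one step that can be read is an at least 1.1-fold higher number from compound 2 to compound 4 (0.05 log units; that floor lies within the scatter), so the added 2-(pyrrolidin-1-yl)ethyl stretch of chain gives no shift that can be told from the scatter. The steps to compound 4 from compound 3 and from compound 1 cannot be read, and the exchange of dimethylamino for (pyrrolidin-1-yl)methyl therefore has no measurable size, as most of the set now shares one ceiling: the limit of > 1 h in this assay, at which 3 of the 4 values shown sit.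

The compounds shown leave open how compound 1, compound 3 and compound 4 would rank if the assay read further than its limit. They also leave open whether a piperidine or morpholine ring at the end of the same chain would reach that limit or return a number.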